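Swapping nitro for hydrogen on compound 3

This account rests on a few compounds, and the source may have more. Where it says the series, first, only, none or still open, it means among the compounds named here.

In a functional assay on CWR22R cells (Homo sapiens) for antiproliferative activity, read by fluorescence and propidium iodide staining, with a stated time of 96 h (a higher number here means a weaker inhibitor, a lower number a stronger inhibitor), compound 1 `O=C(Nc1ccc([N+](=O)[O-])c(C(F)(F)F)c1)c1ccc(Sc2ccc(O)cc2)cc1` gives 4500 nM and compound 2 `O=C(Nc1cccc(C(F)(F)F)c1)c1ccc(Sc2ccc(O)cc2)cc1` gives 5730 nM while compound 3 `O=C(Nc1ccc([N+](=O)[O-])c(C(F)(F)F)c1)c1ccc(S(=O)(=O)c2ccc(O)cc2)cc1` gives 7300 nM and so stands within the scatter of both. Compound 4 `O=C(Nc1cccc(C(F)(F)F)c1)c1ccc(S(=O)(=O)c2ccc(O)cc2)cc1` carries one change from compound 3: hydrogen in place of nitro on an aromatic carbon. The one measured case of this exchange is a 1.3-fold higher number from compound 1 to compound 2 (0.10 log units; within the scatter) and it stayed within the scatter. The step of a 1.6-fold higher number from compound 1 to compound 3 (0.21 log units; within the scatter) with (4-hydroxyphenyl)sulfonyl in place of (4-hydroxyphenyl)sulfanyl also stayed within it. In this assay no step beyond the scatter is therefore expected, and the estimated move is a 1.2-fold higher number from compound 3 to compound 4 (0.09 log units; within the scatter) in the direction of a higher number. Compound 4 is estimated at 9000 nM (expected range 5000 nM to 16000 nM).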

Compound 4, half-maximal inhibitory concentration: 15100 nM
For compound 4 the middle estimate is 1.7-fold (0.22 log units) below the measured one; the measured number falls inside the stated range.
By their numbers in this assay, from the lowest: compounds 1, 2 and 3 (each within the scatter of the next); then compound 4.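

With the sulfonyl group in place, exchanging nitro for hydrogen ortho to a trifluoromethyl group gives a step that clears the scatter in this assay: a 2.1-fold higher number from compound 3 to compound 4 (0.32 log units; beyond the scatter). For the compounds shown here, this is the first sign that losing the nitro group can weaken these compounds, though only modestly. The two cases do not show that the size of this step depends on the core: the same change on two cores in this assay, a 1.3-fold higher number (0.10 log units; within the scatter) from compound 1 to compound 2 and a 2.1-fold higher number (0.32 log units; beyond the scatter) from compound 3 to compound 4, 1.6-fold (0.21 log units) apart, within the scatter of two such steps.

Only nitro and hydrogen appear at this position in the compounds shown. As far as these compounds go, how an amine or a nitrile there would read in this assay remains open.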